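The source may hold more compounds than are shown below. What is called first, only, known or untested is meant among the compounds shown, and "the series" means these compounds.

Three hydroxamic acids built on one shared core have been tested. Compound 1 `Cc1ccccc1CN1CC=C(CCC(=O)NO)C1=O` and compound 3 `Cc1cccc(CN2CC=C(CCC(=O)NO)C2=O)c1` each carry a methyl-substituted benzyl group on the ring nitrogen, while compound 2 `O=C(CCC1=CCN(CCCc2ccc(Br)cc2)C1=O)NO` carries a three-carbon chain ending in a bromophenyl group. In a functional assay on HCT-15 cells (Homo sapiens) for inhibition, read by sulforhodamine B assay (on this read-out higher numbers stand for weaker inhibition of growth and lower numbers for stronger inhibition of growth), compound 1 gives 4720 nM, compound 3 gives 4720 nM, and compound 2 gives 5100 nM. Compound 2 therefore stands alongside compounds 1 and 3: its number differs from each of theirs by less than the usual scatter of this assay, so no separation between the three can be read from these numbers.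

Compound 4 `CC(C)(C)c1ccc(CCCN2CC=C(CCC(=O)NO)C2=O)cc1` follows from compound 2 by one change: tert-butyl in place of bromo on an aromatic carbon. Among the compounds with values here, no measured pair in this set shows what such a replacement does. Since the three measured compounds sit so close together, the step from compound 2 to compound 4 is expected to be none beyond the scatter, which is what a 1.0-fold lower number from compound 2 to compound 4 (0.01 log units; within the scatter) expresses. Compound 4 is thus estimated at 5000 nM in this assay, within a range from 2500 nM to 10000 nM.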

Compound 4, concentration for 50% growth inhibition: 5100 nM
Compound 4: middle estimate off by 1.0-fold (0.01 log units), on the low side; the range from low to high includes it.
By their numbers in this assay, from the lowest: compounds 1, 3, 2 and 4 (each within the scatter of the next).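

In this assay, within the data shown here, replacing bromo with tert-butyl on an aromatic carbon, para to a large group, gives no change at the digits printed from compound 2 to compound 4 (within the scatter) and is the first single-place comparison in the set. Among these compounds, at this position, then, a group of 4 heavy atoms can stand in place of one of 1 heavy atom with no step beyond the scatter in this growth read-out, which the earlier compounds, differing in more than one place, could not show. Nothing measured here accounts for this result.

Bromo and tert-butyl both have no hydrogen-bond donors or acceptors and no net charge, so what an amine or a carboxylic acid at this position would do remains open. Also open, on these data alone, is whether tert-butyl would give the same result on the methyl-substituted benzyl group of compound 1 or compound 3.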